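The source may report more compounds than this note shows. Statements on the series, on what has been measured and on what is new or still open speak of the compounds shown alone.

Working notes on the series. In a functional assay (trachea) for inhibition, with Cavia porcellus as the target (on this read-out higher numbers stand for weaker inhibition and lower numbers for stronger inhibition), compound 2 `CC1(C)C=C(N2CCC2=O)c2cc(C#N)ccc2O1` gives 7500 nM, the highest of the three numbers in hand. Compound 1 `CC1(C)Oc2ccc(C#N)cc2[C@@H](n2ccccc2=O)[C@@H]1O` gives 760 nM and compound 3 `CC1(C)C=C(N2CCCCC2=O)c2cc(C(F)(F)F)ccc2O1` gives 650 nM, both beyond the scatter from compound 2, which thus stands as the weakest inhibitor measured so far. Compound 4 `CC1(C)C=C(n2ccccc2=O)c2cc(C#N)ccc2O1` is not yet measured; it differs from compound 2 by a group of 7 heavy atoms (5 carbon, 1 nitrogen, 1 oxygen; one six-membered aromatic ring with 1 hetero atom) in place of a group of 5 heavy atoms (3 carbon, 1 nitrogen, 1 oxygen; one four-membered non-aromatic ring with 1 hetero atom), on a double-bonded ring carbon, on a double-bonded ring carbon of the fused system. Among the compounds with values here, no pair of measured compounds isolates this change. Because compound 1, carrying the same entering group on a related core, gives 760 nM in this assay, compound 4 is expected to come in lower, by a step of an 8.3-fold lower number from compound 2 to compound 4 (0.92 log units; beyond the scatter). The estimate for compound 4 is 900 nM, within 300 nM to 3000 nM.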

Compound 4, half-maximal inhibitory concentration: 89 nM
Estimate against measurement, compound 4: 10-fold (1.00 log units) above, and the stated range ends above it.
By their numbers in this assay, from the lowest: compound 4; then compounds 3 and 1 (each within the scatter of the next); then compound 2.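

In this assay, within the data shown here, the step of an 84-fold lower number from compound 2 to compound 4 (1.93 log units; beyond the scatter) is the first measured change that isolates the group on the double-bonded ring carbon, with the nitrile and the rest of the core held constant. It shows that the number at this position depends strongly on which ring is attached, and the step is large. No measurement in hand accounts for the size of this step.

A single pair cannot separate ring size from aromatic character in the entering group. Going by these compounds, how a 2-oxopyrrolidin-1-yl group or an open-chain acetylamino group would read at this carbon remains open.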